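Hydrazone aryl swap: bromo-hydroxyphenyl replacing nitrophenyl

The source may hold more compounds than are shown below. What is called first, only, known or untested is meant among the compounds shown, and "the series" means these compounds.

The three measured analogues share one core and differ only in the aryl group on the hydrazone carbon. In a functional assay on PC-3 cells (Homo sapiens) for antiproliferative activity, read by MTT assay (on this read-out lower numbers stand for stronger inhibition and higher numbers for weaker inhibition), compound 1 `Cn1c(=O)c(=O)n(C2CCCC2)c2nc(N/N=C/c3ccc(O)c(F)c3)ncc21` gives 85200 nM, compound 2 `Cn1c(=O)c(=O)n(C2CCCC2)c2nc(N/N=C/c3cccc(O)c3)ncc21` gives 36300 nM, and compound 3 `Cn1c(=O)c(=O)n(C2CCCC2)c2nc(N/N=C/c3cccc([N+](=O)[O-])c3)ncc21` gives 20300 nM. Compound 3 sits at the low end of these numbers; its separation from compound 2 is a 1.8-fold lower number from compound 2 to compound 3 (0.25 log units; within the scatter), so the two are not distinguished, whereas the step beyond the scatter is a 4.2-fold lower number from compound 1 to compound 3 (0.62 log units; beyond the scatter), with a 2.3-fold lower number from compound 1 to compound 2 (0.37 log units; beyond the scatter) in between.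

Compound 4 `Cn1c(=O)c(=O)n(C2CCCC2)c2nc(N/N=C/c3ccc(O)c(Br)c3)ncc21` carries 3-bromo-4-hydroxyphenyl in place of 3-nitrophenyl on a carbon with a double bond to nitrogen. The step that bears on it is the reverse of the move from the fluoro-hydroxyphenyl of compound 1 to the nitrophenyl of compound 3, which gave a 4.2-fold lower number from compound 1 to compound 3 (0.62 log units; beyond the scatter); the hydroxy-bearing compound 2 also gave a 1.8-fold lower number from compound 2 to compound 3 (0.25 log units; within the scatter) against the nitro analogue. Nothing here separates bromine from fluorine on that ring. A rise in the number is therefore expected for compound 4, estimated at a 3.0-fold higher number from compound 3 to compound 4 (0.47 log units; beyond the scatter) because a 4.2-fold lower number from compound 1 to compound 3 (0.62 log units; beyond the scatter) points that way. Compound 4 is expected near 60000 nM, within 20000 nM to 180000 nM.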

Compound 4, half-maximal inhibitory concentration: 11600 nM
Compound 4: middle estimate off by 5.2-fold (0.71 log units), on the high side; measured number outside the range, below it.
By their numbers in this assay, from the lowest: compounds 4, 3 and 2 (each within the scatter of the next, the first and the last beyond it); then compound 1.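

In this assay, the halogen on the hydroxyphenyl ring matters: bromo in place of fluoro on an aromatic carbon gives a 7.3-fold lower number from compound 1 to compound 4 (0.87 log units; beyond the scatter), so the poor result for the 3-fluoro-4-hydroxyphenyl group does not carry over to its bromo counterpart. A hydroxy-bearing aryl group on the hydrazone carbon is therefore not tied to a higher number, since 3-bromo-4-hydroxyphenyl in place of 3-nitrophenyl gives a 1.8-fold lower number from compound 3 to compound 4 (0.24 log units; within the scatter), which does not distinguish the two, while 3-bromo-4-hydroxyphenyl in place of 3-hydroxyphenyl gives a 3.1-fold lower number from compound 2 to compound 4 (0.50 log units; beyond the scatter). No supporting data account for these differences.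

As far as these compounds go, whether the bromo or the hydroxy group carries the effect stays open without a 3-bromophenyl analogue. From the compounds shown here alone, how chloro, iodo, an amine or a carboxylic acid on this ring would compare also remains unknown.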